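Dropping the chloro from compound 2: what a hydrogen changes

The source may hold more compounds than are shown below. What is called first, only, known or untested is meant among the compounds shown, and "the series" means these compounds.

The study measures how long compounds survive in an ADME assay on microsomes from liver (Homo sapiens) for metabolic stability, using NADPH, with a stated time of 40 min, tested at 2 uM; on this read-out higher numbers stand for a longer-lived compound and lower numbers for a shorter-lived compound. Compound 1 `CNC(=O)c1cccc2nc(-c3c[nH]c4c(F)c(F)c(F)cc34)ccc12` gives 1.17 h in this assay. Compound 2 `Cc1cccc2c(-c3ccc4ccc(Cl)cc4n3)c[nH]c12` gives 1.48 h in this assay, a gap from compound 1 that lies within the usual scatter, so the two stand together. Compound 3 `Cc1cccc2c(-c3ccc4ccccc4n3)c[nH]c12` differs from compound 2 by hydrogen in place of chloro on an aromatic carbon. Going by the values given here, no measured pair shows this change, so compound 3 is expected at 1.1 h in this assay, between 0.6 h and 2 h, a step of a 1.3-fold lower number from compound 2 to compound 3 (0.13 log units; within the scatter) estimated as a slight fall that may not exceed the scatter.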

Compound 3, half-life: 0.35 h
For compound 3 the middle estimate is 3.1-fold (0.50 log units) above the measured one; the measured number lies below the stated range.
By their numbers in this assay, from the lowest: compound 3; then compounds 1 and 2 (each within the scatter of the next).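

In this assay, hydrogen in place of chloro on this aromatic carbon gives a 4.2-fold lower number from compound 2 to compound 3 (0.63 log units; beyond the scatter). Going by these compounds alone, this is the first comparison here between compounds that differ in one place, and it shows that the half-life depends on what occupies this carbon. Nothing available explains why the half-life moves with this change.

From the compounds shown here alone, it remains open whether this is particular to chloro or whether a fluoro, a methoxy or a nitrile at this carbon would give a similar half-life. Going by these compounds, whether the step would keep its size with other groups elsewhere on the shared core also remains open.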